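Replacing a nitrogen methyl with hydrogen in compound 1

The compounds below may be only part of what the source reports. "The series", "measured", "known", "first", "only" and "open" are said of these compounds alone.

In a functional assay on KARPAS-422 cells (Homo sapiens) for inhibition, read by resazurin assay, with stated times of 72 h and 96 h (a lower number here means a stronger inhibitor, a higher number a weaker inhibitor), compound 1 `Cc1cc(C)n(C)c(=O)c1CN1CCc2c(Cl)cc(-c3c(C)noc3C)c(Cl)c2C1=O` gives 4680 nM and compound 2 `COc1cc(C)n(C)c(=O)c1CN1CCc2c(Cl)cc(-c3c(C)noc3C)c(Cl)c2C1=O` gives 2950 nM. Among the measured compounds shown here, these are the only two numbers so far, and they sit within the scatter of each other, so compound 1 cannot be ranked apart from compound 2. For the measured compounds named here, the single measured step is a 1.6-fold lower number from compound 1 to compound 2 (0.20 log units; within the scatter).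

Compound 3 `Cc1cc(C)c(CN2CCc3c(Cl)cc(-c4c(C)noc4C)c(Cl)c3C2=O)c(=O)[nH]1` keeps the core of compound 1 and alters one place: hydrogen in place of methyl on an aromatic nitrogen. The measured step, methoxy in place of methyl on an aromatic carbon, concerns a different place. Going by the values given here, compound 1 and compound 2 both carry the methyl on that nitrogen, so no measurement yet tests its removal, and the size of the step remains uncertain. Among the compounds with values here, compound 3 would be the only compound here with the amide hydrogen, so a lower number beyond the scatter is expected, as a judgement and not a measured trend. The expected step is a 23-fold lower number from compound 1 to compound 3 (1.37 log units; beyond the scatter). For compound 3 the estimated value is 200 nM, with an expected range of 20 nM to 3000 nM.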

Compound 3, half-maximal inhibitory concentration: 122 nM
For compound 3 the middle estimate is 1.6-fold (0.21 log units) above the measured one, and the stated range covers the measured number.
By their numbers in this assay, from the lowest: compound 3; then compounds 2 and 1 (each within the scatter of the next).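

In this assay, among the compounds shown here, this nitrogen proves to be a sensitive position: replacing its methyl with hydrogen gives a 38-fold lower number from compound 1 to compound 3 (1.58 log units; beyond the scatter), a large step, whereas the only earlier comparison, at an aromatic carbon, gave a 1.6-fold lower number from compound 1 to compound 2 (0.20 log units; within the scatter). The edit removes just one heavy atom, a single carbon, and leaves the rest of the core of compound 1 untouched, so even a very small change on this aromatic nitrogen can move the number far beyond ordinary assay variation. Nothing measured here accounts for the size of this step.

The compounds shown place only methyl and hydrogen on this nitrogen, so they cannot separate the effect of losing the methyl from that of having the amide hydrogen, and an ethyl group or a longer chain ending in an amine would be needed to show how the number responds to other groups there. On these data alone, it also remains open whether methoxy in place of methyl on the aromatic carbon, the change that separates compound 1 from compound 2, would alter the number in a compound that carries the amide hydrogen.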